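Ring Size on the Amide Nitrogen: Cycloheptyl to Cyclooctyl

The source may report more compounds than this note shows. Statements on the series, on what has been measured and on what is new or still open speak of the compounds shown alone.

Three compounds share one core and differ only in the saturated ring carried on an amide-type nitrogen. In a functional assay on the whole organism for inhibition, with Mus musculus as the target, at a dose of 30 mg/kg by the oral route (a lower number here means less inhibition, a higher number more inhibition at the dose given (going by the name of the read-out)), compound 1 `O=C(NCCCOc1ccc2nc(O)ccc2c1)N(C1CCCC1)[C@H]1CCCC[C@@H]1O` gives 78%, compound 2 `O=C(NCCCOc1ccc2nc(O)ccc2c1)N(C1CCCCC1)[C@H]1CCCC[C@@H]1O` gives 57% and compound 3 `O=C(NCCCOc1ccc2nc(O)ccc2c1)N(C1CCCCCC1)[C@H]1CCCC[C@@H]1O` gives 69%. Compound 3 thus stands within the scatter of compound 1 and beyond the scatter above compound 2. Compound 4 `O=C(NCCCOc1ccc2nc(O)ccc2c1)N(C1CCCCCCC1)[C@H]1CCCC[C@@H]1O` extends the series: cyclooctyl in place of cycloheptyl on an amide-type nitrogen. For the measured compounds named here, the steps that bear on it are a number 9 percentage points lower from compound 1 to compound 3 (within the scatter) and a number 12 percentage points higher from compound 2 to compound 3 (beyond the scatter); growing the ring has so far given no steady direction, once a modest change, once none beyond the scatter. For compound 4 in this assay a step of about a number 4 percentage points lower from compound 3 to compound 4 (within the scatter) is expected, essentially no change beyond the scatter. The estimate for compound 4 is 65%, within an expected range from 45% to 85%.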

Compound 4, a percentage reported as inhibition, in the whole organism at one dose (the size of the read-out at that dose, not a potency): 100%
The estimate for compound 4 lay 35 percentage points below the measured number; measured number outside the range, above it.
By their numbers in this assay, from the lowest: compound 2; then compounds 3 and 1 (each within the scatter of the next); then compound 4.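

In this assay, cyclooctyl on the amide-type nitrogen stands clear of all three smaller rings, with a number 31 percentage points higher from compound 3 to compound 4 (beyond the scatter) and a number 43 percentage points higher from compound 2 to compound 4 (beyond the scatter) and also a number 22 percentage points higher from compound 1 to compound 4 (beyond the scatter) in this series. One more ring carbon at this position can therefore produce a large step, even though the trend across the four compounds is not steady, since compound 2 with cyclohexyl lies lowest. No available measurement explains this step.

The compounds shown leave open whether a larger ring such as cyclononyl would keep this level. They also leave open whether the ring itself matters, which a straight octyl chain on the same nitrogen could test.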